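This account rests on a few compounds, and the source may have more. Where it says the series, first, only, none or still open, it means among the compounds named here.

Measured so far:
- compound 1, `O=C(O)Cc1sc(C2COc3ccccc3O2)nc1-c1ccc(Cl)cc1`: 2000 nM
- compound 2, `O=C(O)Cc1sc(C(c2ccccc2)c2ccccc2)nc1-c1ccc(C(F)(F)F)cc1`: a limit only
- compound 3, `N#Cc1ccc(-c2nc(C(c3ccc(F)cc3)c3ccc(F)cc3)sc2CC(=O)O)cc1`: 1500 nM

The series is measured in an in vitro functional assay on HEK285-7 cells for antagonist activity at prostaglandin D2 receptor 2 (Homo sapiens), read by BRET and beta-arrestin recruitment; a lower number here means a stronger inhibitor, a higher number a weaker inhibitor. Compound 1 gives 2000 nM. Compound 2 gives only a limit, > 100000 nM, and so stands at the limit of > 100000 nM in this assay, at which 1 of the 3 values shown sits. Compound 3 gives 1500 nM, the lower of the two numbers, though its gap to compound 1 lies within the scatter, so the two are not distinguished.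

Compound 4, `CN(C)c1cc(-c2nc(C(c3ccc(F)cc3)c3ccc(F)cc3)sc2CC(=O)O)ccn1`, differs from compound 3 in one place: 2-(dimethylamino)pyridin-4-yl in place of 4-cyanophenyl on an aromatic carbon. Among the measured compounds shown here, no measured pair in this set makes the same move, so the size of the step is open. Compound 3 is expected to go to compound 4 with a step of a 1.3-fold higher number from compound 3 to compound 4 (0.12 log units; within the scatter), not clearly beyond the scatter. Compound 4 is therefore estimated at 2000 nM, between 500 nM and 8000 nM.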

Compound 4, half-maximal inhibitory concentration: > 100000 nM
Compound 4: only a limit was reported; the forecaster's own chance of this, stated with the estimate: 10%; middle value at least 50-fold (1.69 log units) from the limit.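

In this assay, the aromatic carbon next to the ring nitrogen proves sensitive to what it carries: 2-(dimethylamino)pyridin-4-yl in place of 4-cyanophenyl gives an at least 66-fold higher number from compound 3 to compound 4 (1.82 log units; beyond the scatter). Among the compounds shown here, this is the first change made in one place only, and with the rest of compound 3 kept, that single change accounts for the whole loss. The value of compound 4 is a limit of the assay, so the true size of the step stays unfixed: the limit of > 100000 nM in this assay, at which 2 of the 4 values shown sit.

The compounds shown leave open whether the loss follows the ring nitrogen or the dimethylamino group. A plain pyridin-4-yl or a 4-(dimethylamino)phenyl at this position would separate the two.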